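Chalcone-type amides: methyl to methoxy on the aryl ring

The compounds below may be only part of what the source reports. "The series", "measured", "known", "first", "only" and "open" are said of these compounds alone.

Measured so far:
Compound 1 `O=C(/C=C/c1cccc(NC(=O)c2ccccc2Cl)c1)c1nc2ccccc2[nH]1` gives 1280 nM in a functional assay on HCT-116 cells (Homo sapiens) for antiproliferative activity, read by MTT assay, with a stated time of 48 h; on this read-out higher numbers stand for weaker inhibition and lower numbers for stronger inhibition.
Compound 2 `O=C(Nc1cccc(/C=C/C(=O)c2nc3ccccc3[nH]2)c1)c1ccc(Cl)cc1` gives 2270 nM in this assay.
Compound 3 `Cc1cccc(C(=O)Nc2cccc(/C=C/C(=O)c3nc4ccccc4[nH]3)c2)c1` gives 1420 nM in this assay.

Compound 3 stands second highest of the three numbers, closest to compound 1 and furthest from compound 2, but every gap among these three lies within the scatter, so no order among them can be read from the data. The three compounds share one core and differ only in the aryl group on the amide carbonyl: 2-chlorophenyl, 4-chlorophenyl or 3-methylphenyl.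

Compound 4 `COc1cccc(C(=O)Nc2cccc(/C=C/C(=O)c3nc4ccccc4[nH]3)c2)c1` is not yet measured. It differs from compound 3 by methoxy in place of methyl on an aromatic carbon. Among the measured compounds shown here, the steps that bear on this change are the other exchanges at the same aryl group: a 1.8-fold higher number from compound 1 to compound 2 (0.25 log units; within the scatter), a 1.1-fold higher number from compound 1 to compound 3 (0.05 log units; within the scatter) and a 1.6-fold lower number from compound 2 to compound 3 (0.20 log units; within the scatter). None of them moved the number beyond the scatter. Compound 4 is therefore expected to stay close to compound 3, with an estimated step of a 1.1-fold higher number from compound 3 to compound 4 (0.02 log units; within the scatter). For compound 4 the estimate is 1500 nM, with a range from 700 nM to 3500 nM.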

Compound 4, half-maximal inhibitory concentration: 3680 nM
For compound 4 the middle estimate is 2.5-fold (0.39 log units) below the measured one, outside the stated range (above it).
By their numbers in this assay, from the lowest: compounds 1, 3, 2 and 4 (each within the scatter of the next, the first and the last beyond it).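

In this assay, the exchange of methyl for methoxy on this aromatic carbon gives a 2.6-fold higher number from compound 3 to compound 4 (0.41 log units; beyond the scatter), so, unlike the exchanges among the three earlier aryl groups, it carries the number beyond the scatter. The 3-methoxyphenyl group also separates from the 2-chlorophenyl group, with a 2.9-fold higher number from compound 1 to compound 4 (0.46 log units; beyond the scatter), but not from the 4-chlorophenyl group, with a 1.6-fold higher number from compound 2 to compound 4 (0.21 log units; within the scatter), so compound 2 and compound 4 cannot be ordered, and the aryl group on the amide carbonyl now shows a real but modest spread. No measurement at hand explains why this exchange goes with weaker inhibition in these cells.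

As far as these compounds go, it remains open whether a hydroxy group, an ethoxy group or an amine on the same aromatic carbon would give a number near that of compound 3 or near that of compound 4. Also open is whether methoxy in place of methyl would shift the number in the same direction on any other aryl group, as this is the only such pair shown.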